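The compounds below may be only part of what the source reports. "The series", "measured", "known", "first", "only" and "open" are said of these compounds alone.

Going by the values given here, in a functional assay on HT-29 cells (Homo sapiens) for inhibition, read by MTT assay, with a stated time of 72 h (on this read-out lower numbers stand for stronger inhibition and higher numbers for weaker inhibition), compound 2 `COc1cc2c(Oc3ccc(NC(=O)c4nn(-c5ccccc5C(F)(F)F)c(=O)cc4C)cc3F)ccnc2cc1OCCCN1CCC(C)CC1` stands lowest of the two numbers known, at 180 nM; compound 1 `COc1cc2c(Oc3ccc(NC(=O)c4nn(-c5ccccc5C)c(=O)cc4C)cc3F)ccnc2cc1OCCCN1CCN(C)CC1`, with its different tail and ring substituent, gives the higher number, 3790 nM. Compound 3 `COc1cc2c(Oc3ccc(NC(=O)c4nn(-c5ccccc5C(F)(F)F)c(=O)cc4C)cc3F)ccnc2cc1OCCCN1CCN(C)CC1` keeps the trifluoromethyl of compound 2 and changes only the tail: 4-methylpiperazin-1-yl in place of 4-methylpiperidin-1-yl on a saturated chain carbon, three bonds along the chain from an oxygen on an aromatic ring. Among the compounds with values here, no measured pair shows this exchange on its own, so its effect is unknown. A step of modest size, if any, is expected from compound 2 to compound 3, a 2.2-fold higher number from compound 2 to compound 3 (0.35 log units; beyond the scatter), towards a somewhat higher number. Compound 3 is therefore estimated at 400 nM, within 120 nM to 1500 nM.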

Compound 3, half-maximal inhibitory concentration: 170 nM
The estimate for compound 3 lay 2.4-fold (0.37 log units) above the measured number, and the stated range covers the measured number.
By their numbers in this assay, from the lowest: compounds 3 and 2 (each within the scatter of the next); then compound 1.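

In this assay the exchange of 4-methylpiperidin-1-yl for 4-methylpiperazin-1-yl on the saturated chain carbon gives a 1.1-fold lower number from compound 2 to compound 3 (0.02 log units; within the scatter) and so makes no difference beyond the scatter. Trifluoromethyl in place of methyl on an aromatic carbon, now seen on its own, gives a 22-fold lower number from compound 1 to compound 3 (1.35 log units; beyond the scatter) with the 4-methylpiperazin-1-yl tail held constant. No measurement shown gives a reason for either step. As far as these compounds go, whether a morpholine tail or a shorter chain would fare alike remains open. So does whether a chlorine or an ethyl group could replace the trifluoromethyl.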